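The compounds below may be only part of what the source reports. "The series", "measured", "known", "first", "only" and "open" are said of these compounds alone.

In a functional assay on MCF7 cells (Homo sapiens) for antiproliferative activity (on this read-out higher numbers stand for weaker inhibition and lower numbers for stronger inhibition), compound 1 (`Cc1cc(S(=O)(=O)c2ccc(C#N)cc2)c2ccccc2n1`) gives 1380 nM and compound 2 (`CCONC(=O)c1sc(N2N=C(c3ccc(C)cc3)CC2c2cc3cc(OC)ccc3nc2Cl)nc1C`) gives 38 nM as its reading. Within the data shown here, compound 2 holds the lower of these two numbers, and the gap between the pair lies beyond the usual scatter, so it is the stronger inhibitor of the two measured so far. Compound 3 (`COc1ccc2nc(Cl)c(C3CC(c4ccc(C)cc4)=NN3c3nc(-c4ccc(C)cc4)cs3)cc2c1`) has not yet been measured in this assay and differs from compound 2 in one place, on an amine nitrogen in a ring. The counted change is 4-(4-methylphenyl)-1,3-thiazol-2-yl in place of 5-(ethoxycarbamoyl)-4-methyl-1,3-thiazol-2-yl on an amine nitrogen in a ring in full, with 4-(4-methylphenyl)-1,3-thiazol-2-yl in place of 5-(ethoxycarbamoyl)-4-methyl-1,3-thiazol-2-yl. Among the measured compounds shown here, no measured pair shows an exchange of this kind, so the expectation starts from compound 2 at 38 nM and remains loose. A moderate loss toward weaker inhibition is expected, and the estimated change is a 3.2-fold higher number from compound 2 to compound 3 (0.50 log units; beyond the scatter) with wide uncertainty. In this assay compound 3 is estimated at 120 nM within an expected range of 25 nM to 600 nM for a single measurement.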

Compound 3, half-maximal inhibitory concentration: 38 nM
Compound 3: the middle estimate sits 3.2-fold (0.50 log units) above what was measured; low and high end bracket the measured number.
By their numbers in this assay, from the lowest: compounds 2 and 3 (each within the scatter of the next); then compound 1.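

In this assay, putting 4-(4-methylphenyl)-1,3-thiazol-2-yl in place of 5-(ethoxycarbamoyl)-4-methyl-1,3-thiazol-2-yl on an amine nitrogen in a ring gives no change at the digits printed from compound 2 to compound 3 (within the scatter) and thus shows that this position can carry either group with no separation between the readings. The entering group has the same count of heavy atoms but adds a six-membered aromatic ring of carbon only and has no hydrogen-bond donor, so in this one pair the reading does not depend on keeping the ethoxycarbamoyl group or the hydrogen-bond donor it carries. Nothing available here explains why two such different groups read alike.

This single exchange cannot say how far that freedom extends, for instance whether a carboxylic acid, a primary amine or a longer alkyl chain on the thiazole would hold the reading as well. It also leaves open whether the 4-methylphenyl group on the five-membered non-aromatic ring can be changed with as little effect as the group on the ring nitrogen.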